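Shifting the ethylamino group on the outer phenyl ring

The source may report more compounds than this note shows. Statements on the series, on what has been measured and on what is new or still open speak of the compounds shown alone.

In a functional assay on HL-60 cells (Homo sapiens) for cytotoxicity, read by CellTiter-Blue, with a stated time of 48 h (on this read-out higher numbers stand for weaker inhibition and lower numbers for stronger inhibition), compound 1 `C#CCOC(=O)CC1C(C(=O)OCC)=C(N)Oc2ccc(-c3cccc(N)c3)cc21` gives 3400 nM, while compound 2 `C#CCOC(=O)CC1C(C(=O)OCC)=C(N)Oc2ccc(-c3cccc(NCC)c3)cc21` gives 17200 nM. Compound 2 therefore stands at the higher of the two numbers, making it the weaker inhibitor of this pair. Within the data shown here, the only measured step is a 5.1-fold higher number from compound 1 to compound 2 (0.70 log units; beyond the scatter), and it comes with ethyl in place of hydrogen on a nitrogen on an aromatic ring.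

Compound 3 `C#CCOC(=O)CC1C(C(=O)OCC)=C(N)Oc2ccc(-c3ccc(NCC)cc3)cc21` has the same atoms as compound 2, joined differently: 4-(ethylamino)phenyl in place of 3-(ethylamino)phenyl on an aromatic carbon. In words, 4-(ethylamino)phenyl stands in place of 3-(ethylamino)phenyl on an aromatic carbon. The measured step offers only limited guidance, since it changes what sits on the nitrogen and not where the group sits on the ring. Among the measured compounds shown here, no measured pair shows a shift of this kind, so neither its size nor its direction is known. A change beyond the scatter is therefore not expected, with only a slight lean towards a lower number in this assay. The expected step is a 1.4-fold lower number from compound 2 to compound 3 (0.16 log units; within the scatter). For compound 3, the estimated value is 12000 nM, with an expected range of 4500 nM to 30000 nM.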

Compound 3, half-maximal inhibitory concentration: 33000 nM
Estimate against measurement, compound 3: 2.8-fold (0.44 log units) below; measured number outside the range, above it.
By their numbers in this assay, from the lowest: compound 1; then compounds 2 and 3 (each within the scatter of the next).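

In this assay, replacing the 3-(ethylamino)phenyl of compound 2 with the 4-(ethylamino)phenyl of compound 3 gives a 1.9-fold higher number from compound 2 to compound 3 (0.28 log units; within the scatter), so this shift of the ethylamino group produces no change that can be told apart from ordinary measurement scatter. The wider comparison gives a 9.7-fold higher number from compound 1 to compound 3 (0.99 log units; beyond the scatter), and since the steps from compound 1 to both other compounds lie beyond the scatter, compound 1, with its 3-aminophenyl group, is the strongest inhibitor of the three, while adding the ethyl group is the only one of the two single changes on the ethylamino side that clearly shows up in the numbers. Nothing available here explains why these compounds differ or why moving the group leaves no clear mark.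

The compounds shown leave open whether a smaller methyl or a longer propyl chain on the nitrogen would fall closer to compound 1 or to compound 2. They also leave open how a carboxylic acid in place of the amine would read in this assay.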